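A few compounds are considered here, and "the series" means these few. Any claim that something is new, unique, unknown or untested is made for them only; others in the source may bear on it.

Among the measured compounds shown here, in a functional assay on DWD cells (Homo sapiens) for inhibition, read by sulforhodamine B assay (a higher number here means a weaker inhibitor of growth, a lower number a stronger inhibitor of growth), compound 1 `c1ccc(-c2ccc(-c3ccc(-c4nc5ccccc5[nH]4)cc3)cc2)cc1` gives 100000 nM, the higher of the two numbers measured so far. Compound 2 `COc1cc(-c2ccc(-c3ccc(-c4nc5cc(C)ccc5[nH]4)cc3)cc2)cc(OC)c1OC` gives 170 nM, far lower and well beyond the scatter. However, compound 2 differs from compound 1 in more than one place, so the gap cannot be assigned to any single change. Compound 3 `FC(F)(F)Oc1ccc(-c2ccc(-c3ccc(-c4nc5ccccc5[nH]4)cc3)cc2)cc1` has not yet been measured. It keeps the core of compound 1, with trifluoromethoxy in place of hydrogen on an aromatic carbon, para to a large group: trifluoromethoxy in place of hydrogen on an aromatic carbon. For the measured compounds named here, no measured pair isolates such a change, so the expectation is loose. With compound 2 at 170 nM, a move towards lower numbers seems more likely than not, but a smaller one than that gap. The expected size of this move is a 10-fold lower number from compound 1 to compound 3 (1.00 log units; beyond the scatter). Compound 3 is estimated at 10000 nM, with an expected range of 800 nM to 100000 nM.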

Compound 3, concentration for 50% growth inhibition: 100000 nM
Estimate against measurement, compound 3: 10-fold (1.00 log units) below; measured number inside the range.
By their numbers in this assay, from the lowest: compound 2; then compounds 1 and 3 (each within the scatter of the next).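

In this assay, placing trifluoromethoxy on an aromatic carbon, para to a large group, gives no change at the digits printed from compound 1 to compound 3 (within the scatter). Among the compounds shown here, this is the first change at this position that can be read on its own, since the earlier pair differs in more than one place. It shows that this group, with its 5 heavy atoms, leaves the growth-inhibition number of the core of compound 1 where it was, and no measurement at hand offers an explanation for this.

Going by these compounds, whether an amine or a carboxylic acid at the same position would likewise leave the number unchanged remains open. Also open, on these data alone, is which of the several differences between compound 1 and compound 2 carries the gap between them, and whether trifluoromethoxy would behave the same way on the core of compound 2.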